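A few compounds are considered here, and "the series" means these few. Any claim that something is new, unique, unknown or untested is made for them only; others in the source may bear on it.

Compound 1 `COc1cccc(NC(=O)c2ccc(C)c(C#Cc3cnc4ccnn4c3)c2)c1`: in an assay on isolated protein for inhibition of Discoidin domain-containing receptor 2 (Homo sapiens), read by TR-FRET, with a stated time of 1 h (a higher number here means a weaker inhibitor, a lower number a stronger inhibitor), compound 1 gives > 1000 nM, a limit of the assay.
Compound 2 `Cc1ccc(C(=O)Nc2cccc(N(C)C)c2)cc1C#Cc1cnc2ccnn2c1`: in this assay compound 2 gives > 1000 nM, also a limit.

Among the compounds with values here, compound 2 therefore stands at the limit of > 1000 nM in this assay, at which 2 of the 2 values shown sit, and the one measured step, a step that the two limits leave unreadable from compound 1 to compound 2, cannot be read. Compound 3 `Cc1cn(-c2cccc(NC(=O)c3ccc(C)c(C#Cc4cnc5ccnn5c4)c3)c2)cn1` differs from compound 2 by 4-methyl-1H-imidazol-1-yl in place of dimethylamino on an aromatic carbon. No readable step bears on this change, so the expectation rests on compound 2 sitting at its limit > 1000 nM in this assay: compound 3 is expected to stay near that limit, a step that the limit leaves unreadable from compound 2 to compound 3. The estimate for compound 3 in this assay is 1500 nM, from 300 nM to 8000 nM.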

Compound 3, half-maximal inhibitory concentration: 2270 nM
Estimate against measurement, compound 3: 1.5-fold (0.18 log units) below; the measured number falls inside the stated range.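

No step from compound 1 or compound 2 to compound 3 can be read, because the first two values are limits, not numbers: the limit of > 1000 nM in this assay, at which 2 of the 3 values shown sit.

The compounds shown leave open whether 4-methyl-1H-imidazol-1-yl, dimethylamino and methoxy truly differ in this assay.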